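A methyl group added to the chain of compound 1

The source may hold more compounds than are shown below. What is called first, only, known or untested is meant among the compounds shown, and "the series" means these compounds.

Measured in a functional assay on A2780 cells (Homo sapiens) for inhibition, read by WST assay, with a stated time of 72 h (a higher number here means a weaker inhibitor, a lower number a stronger inhibitor), are two compounds:
- compound 1 `N#C/N=C(\NCCCCCCC(=O)NOC1CCCCC1)Nc1ccncc1` gives 35 nM
- compound 2 `N#C/N=C(\NCCCCCCC(=O)N(Cc1ccccc1)OC1CCCCC1)Nc1ccncc1` gives 0.055 nM

Compound 1 holds the higher of the two numbers, so it is the weaker inhibitor. Compound 3 `C[C@@H](CCCCCN/C(=N\C#N)Nc1ccncc1)C(=O)NOC1CCCCC1` differs from it by one change (methyl in place of hydrogen on a saturated chain carbon bound to a carbonyl carbon and a saturated chain carbon): methyl in place of hydrogen on a saturated chain carbon bound to a carbonyl carbon and a saturated chain carbon. Within the data shown here, the only measured step, a 640-fold lower number from compound 1 to compound 2 (2.80 log units; beyond the scatter), put benzyl in place of hydrogen on an amide-type nitrogen. Among the measured compounds shown here, that is a different place, so it shows only that one change can matter greatly in this assay and sets no size here. No step beyond the scatter is expected, though with wide uncertainty. The expected step is a 1.1-fold higher number from compound 1 to compound 3 (0.06 log units; within the scatter) in size. For compound 3 the estimate is 40 nM, with an expected range from 6 nM to 250 nM in all.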

Compound 3, half-maximal inhibitory concentration: 0.08 nM
Compound 3: the middle estimate sits 500-fold (2.70 log units) above what was measured; measured number outside the range, below it.
By their numbers in this assay, from the lowest: compounds 2 and 3 (each within the scatter of the next); then compound 1.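

In this assay the step of a 440-fold lower number from compound 1 to compound 3 (2.64 log units; beyond the scatter) comes from a single methyl on a saturated chain carbon bound to a carbonyl carbon and a saturated chain carbon. This shows that the chain, and not only the amide-type nitrogen, can respond strongly to one small change, here a group of just 1 heavy atom with no ring. No measurement here explains this gain. On these data alone, whether an ethyl group, a hydroxyl group or a fluorine atom on this carbon would act the same remains open, as does the effect of the mirror-image arrangement of the methyl.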